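Carboxy for trifluoromethyl on the pyridinyl amine

A few compounds are considered here, and "the series" means these few. Any claim that something is new, unique, unknown or untested is made for them only; others in the source may bear on it.

The shared core, seen in compound 1 `COc1cccc(Nc2cc3[nH]c(-c4cccc(C(F)(F)F)c4)nc3cn2)n1` and compound 2 `FC(F)(F)c1ccc(Nc2cc3[nH]c(-c4cccc(C(F)(F)F)c4)nc3cn2)nc1`, carries an amine substituent that varies. In a physicochemical assay for solubility, using the shake flask method, in phosphate buffer, measured as kinetic solubility, with a stated time of 20 h, at pH 6.5 (a lower number here means a less soluble compound, a higher number a more soluble compound), compound 1 gives only the limit < 5000 nM. In this assay compound 2 likewise gives only the limit < 5000 nM. Within the data shown here, the one measured step, a step that the two limits leave unreadable from compound 1 to compound 2, stays unreadable, since both values sit at the limit of < 5000 nM in this assay, at which 2 of the 2 values shown sit. Compound 3 `O=C(O)c1ccc(Nc2cc3[nH]c(-c4cccc(C(F)(F)F)c4)nc3cn2)nc1` differs from compound 2 by carboxy in place of trifluoromethyl on an aromatic carbon. No readable measured step bears on this change in this assay, so its size is open. Compound 3 is expected at 20000 nM, between 3000 nM and 150000 nM, an expected step of an at least 4.0-fold higher number from compound 2 to compound 3 (0.60 log units; beyond the scatter), with a fair chance of another limit.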

Compound 3, solubility: 6000 nM
Beside the measured number, compound 3's estimate is 3.3-fold (0.52 log units) above it; measured number inside the range.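

In this assay, among these compounds, compound 3 is the first to give a number and not a limit, 6000 nM. Carboxy in place of trifluoromethyl gives an at least 1.2-fold higher number from compound 2 to compound 3 (0.07 log units; that floor lies within the scatter), and 5-carboxypyridin-2-yl in place of 6-methoxypyridin-2-yl gives an at least 1.2-fold higher number from compound 1 to compound 3 (0.07 log units; that floor lies within the scatter). Both steps are only floors, set by one shared limit: the limit of < 5000 nM in this assay, at which 2 of the 3 values shown sit.

As far as these compounds go, the full size of these steps stays open, and the step between the two compounds at the limit cannot be read. Whether a primary amide or an amine at this position also gives a readable number is open too.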